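Compound 4: losing the remaining bromo at the assay limit

The source may hold more compounds than are shown below. What is called first, only, known or untested is meant among the compounds shown, and "the series" means these compounds.

In a functional assay on MCF7 cells (Homo sapiens) for cytotoxicity, read by MTT assay, with a stated time of 24 h (a higher number here means a weaker inhibitor, a lower number a stronger inhibitor), compound 1 (`O=c1nc2ccc(Br)cn2cc1Cc1ccc(Br)cc1`) gives 97200 nM. Compound 2 (`O=c1nc2ccc(Br)cn2cc1Cc1ccc(Cl)cc1`) gives > 1000000 nM, which is a limit and not a number. Compound 3 (`O=c1nc2ccc(Br)cn2cc1Cc1ccccc1`) gives > 1000000 nM, also a limit and not a number. That places compound 3 at the limit of > 1000000 nM in this assay, at which 2 of the 3 values shown sit.

Compound 4 (`O=c1nc2ccccn2cc1Cc1ccccc1`) differs from compound 3 by one change: hydrogen in place of bromo on an aromatic carbon. The closest measured step is an at least 10-fold higher number from compound 1 to compound 3 (1.01 log units; beyond the scatter), with hydrogen in place of bromo. Also relevant is an at least 10-fold higher number from compound 1 to compound 2 (1.01 log units; beyond the scatter), with chloro in place of bromo. Both are large, but both replace the other bromo of compound 1, not the one leaving here. On these data alone, both also end at a limit, so their full size remains open. No bromo loss starting from a compound at the limit has been measured. In this assay the expectation is therefore a higher number or no readable step. The expected change is a step that the limit leaves unreadable from compound 3 to compound 4. For compound 4 the estimated value is 1500000 nM, with an expected range of 500000 nM to 5000000 nM.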

Compound 4, half-maximal inhibitory concentration: 75400 nM
Compound 4: middle estimate off by 20-fold (1.30 log units), on the high side; measured number below the stated range.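

On an aromatic carbon of the six-membered aromatic ring with 1 nitrogen, para to a fused ring, hydrogen in place of bromo gives an at least 13-fold lower number from compound 3 to compound 4 (1.12 log units; beyond the scatter) in this assay. The same exchange at the other bromo runs the opposite way, an at least 10-fold higher number from compound 1 to compound 3 (1.01 log units; beyond the scatter), so across these compounds the direction of this change depends on which bromo leaves. Compound 3 gives > 1000000 nM, a limit and not a number, so the new step is a bound on its size and not a full measure: the limit of > 1000000 nM in this assay, at which 2 of the 4 values shown sit.

On these data alone, what a methyl, a methoxy or an amine would do in this place remains open. Also open, as far as these compounds go, is whether a chloro here would follow hydrogen or bromo, and whether the same direction holds when the other ring carries a substituent.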